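Bromo for Trifluoromethoxy on a Shared Core

The source may hold more compounds than are shown below. What is called first, only, known or untested is meant among the compounds shown, and "the series" means these compounds.

The three measured compounds share one core and differ only in their aryl substituents. Compound 1 `CC(c1ccc(-c2ccccc2)c(F)c1)c1nnc2n1N=C(c1ccc(Cl)cc1)CS2` gives 3800 nM in a functional assay on SNU-475 cells (Homo sapiens) for inhibition, read by sulforhodamine B assay, with a stated time of 72 h; a lower number here means a stronger inhibitor, a higher number a weaker inhibitor. Among the measured compounds shown here, compound 2 `CC(c1ccc(-c2ccccc2)c(F)c1)c1nnc2n1N=C(c1ccc(Cl)cc1Cl)CS2` gives 4700 nM in this assay, and the step of a 1.2-fold higher number from compound 1 to compound 2 (0.09 log units; within the scatter) is the only single-change step among them. Compound 3 `CC(C)Cc1ccc(C(C)c2nnc3n2N=C(c2ccc(OC(F)(F)F)cc2)CS3)cc1` gives 6800 nM in this assay, the highest of the three numbers, though its gaps to compound 2 and compound 1 both stay within the scatter.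

Compound 4 `CC(C)Cc1ccc(C(C)c2nnc3n2N=C(c2ccc(Br)cc2)CS3)cc1` differs from compound 3 by bromo in place of trifluoromethoxy on an aromatic carbon. For the measured compounds named here, no measured step swaps these two groups, so the only guide is the step from compound 1 to compound 2, which stayed within the scatter when a halogen was added, and the values of compound 1 and compound 3, which also lie within the scatter of each other. Compound 4 is therefore expected to show a step of a 1.4-fold lower number from compound 3 to compound 4 (0.13 log units; within the scatter) that does not clearly exceed the scatter. The value of compound 4 in this assay is estimated at 5000 nM, with a range from 2400 nM to 11000 nM.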

Compound 4, half-maximal inhibitory concentration: 10100 nM
Compound 4: the middle estimate sits 2.0-fold (0.31 log units) below what was measured; the range from low to high includes it.
By their numbers in this assay, from the lowest: compounds 1, 2, 3 and 4 (each within the scatter of the next, the first and the last beyond it).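

In this assay, replacing trifluoromethoxy with bromo on the aromatic carbon para to a large group gives a 1.5-fold higher number from compound 3 to compound 4 (0.17 log units; within the scatter). Among the compounds shown here, this is the first direct reading of this exchange, and it shows that a group of 5 heavy atoms with 1 hydrogen-bond acceptor can give way to a single bromine atom, with no hydrogen-bond acceptor, without the step leaving the scatter. The compounds shown offer no measurement that would explain this result.

Going by these compounds, it remains open whether the same exchange would also stay within the scatter on the aryl group carried by compound 1 and compound 2. On these data alone, it is also open whether a quite different group at this position, such as an amine or a carboxylic acid, would produce a step beyond the scatter.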